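The source may report more compounds than this note shows. Statements on the series, on what has been measured and on what is new or still open speak of the compounds shown alone.

Among the compounds with values here, compound 1 `O=C1CC(c2nc(-c3cccc(Cl)c3)no2)CN1c1cccc(Cl)c1` gives 1100 nM in an in vitro functional assay on HEK293-A cells for negative allosteric modulation of metabotropic glutamate receptor 5 (Homo sapiens), read by FLIPR and calcium flux (on this read-out lower numbers stand for stronger inhibition and higher numbers for weaker inhibition), the highest of the two numbers measured so far, with compound 2 `O=C1CC(c2nc(-c3cccc(Cl)c3)no2)CN1c1ccccc1Cl` nearest at 680 nM. Within the data shown here, the only measured step, a 1.6-fold lower number from compound 1 to compound 2 (0.21 log units; within the scatter), stays within the scatter. Compound 3 `Cc1ccc(N2CC(c3nc(-c4cccc(Cl)c4)no3)CC2=O)cc1C` differs from compound 1 by 3,4-dimethylphenyl in place of 3-chlorophenyl on an amide-type nitrogen in a ring. Among the measured compounds shown here, no measured step replaces 3-chlorophenyl with 3,4-dimethylphenyl, so the step from compound 1 to compound 2 is the only guide, and it points to little movement when the group on that nitrogen is varied. Compound 3 is therefore expected to give 900 nM, somewhere between 350 nM and 2500 nM, a step of a 1.2-fold lower number from compound 1 to compound 3 (0.09 log units; within the scatter) that lies within the scatter.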

Compound 3, half-maximal inhibitory concentration: > 10000 nM
Compound 3 was reported as a limit (the forecaster's own chance of this, stated with the estimate: 5%); middle value at least 11-fold (1.04 log units) from the limit.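

Compound 3 is reported only as a limit: the limit of > 10000 nM in this assay, at which 1 of the 3 values shown sits. The group on the amide-type nitrogen in a ring clearly matters: 3,4-dimethylphenyl gives an at least 9.0-fold higher number from compound 1 to compound 3 (0.95 log units; beyond the scatter) and an at least 14-fold higher number from compound 2 to compound 3 (1.16 log units; beyond the scatter), whereas 2-chlorophenyl and 3-chlorophenyl lie within the scatter of each other. This position therefore accepts both chlorophenyl groups shown, but not every substituted phenyl.

As far as these compounds go, whether the drop follows from losing the chlorine, from one methyl group or from the two together stays open. Plain phenyl, 3-methylphenyl, 4-methylphenyl and 4-chlorophenyl would help separate these possibilities.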